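The compounds below may be only part of what the source reports. "The series", "measured", "known", "first", "only" and "open" are said of these compounds alone.

Three compounds have been measured in a functional assay on UACC-62 cells (Homo sapiens) for inhibition, read by sulforhodamine B assay, with a stated time of 48 h; a higher number here means a weaker inhibitor of growth, a lower number a stronger inhibitor of growth:

Compound 1 `COc1ccc(-c2[nH]c3ccccc3c2/C=C(\C#N)S(=O)(=O)c2ccccc2)cc1` gives 597 nM.
Compound 2 `CC(=O)/C(=C\c1c(-c2ccccc2)[nH]c2ccccc12)S(=O)(=O)c1ccccc1` gives 1000 nM.
Compound 3 `O=C(/C(=C\c1c(-c2ccccc2)[nH]c2ccccc12)S(=O)(=O)c1ccccc1)c1ccccc1` gives 9000 nM.

Compound 3 stands at the highest number of the three: compound 2 sits at a 9.0-fold higher number from compound 2 to compound 3 (0.95 log units; beyond the scatter) below it, and compound 1 lies further below still. Among the compounds with values here, the only single-point step among the measured compounds is the one from compound 2 to compound 3, where a 9.0-fold higher number from compound 2 to compound 3 (0.95 log units; beyond the scatter) accompanied a phenyl in place of methyl on a carbonyl carbon.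

Compound 4 `N#C/C(=C\c1c(-c2ccccc2)[nH]c2ccccc12)S(=O)(=O)c1ccccc1` differs from compound 3 by cyano in place of benzoyl on a double-bonded chain carbon bound to a double-bonded chain carbon and a sulfonyl sulfur. Within the data shown here, no measured pair shows exactly this exchange. Compound 1, however, already carries a cyano group at the same place while differing from compound 4 elsewhere, and it gives the lowest number of the three. Compound 2, with the smaller acetyl group at this place, also gives a lower number than compound 3. Taken together these values suggest that removing the benzoyl group should bring the number down markedly in this assay.

Compound 4 is therefore expected to show a 13-fold lower number from compound 3 to compound 4 (1.11 log units; beyond the scatter), landing near the values of compounds 1 and 2. The estimate for compound 4 in this assay is 700 nM, with a range of 300 nM to 2000 nM.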

Compound 4, concentration for 50% growth inhibition: 2600 nM
For compound 4 the middle estimate is 3.7-fold (0.57 log units) below the measured one; the whole stated range lies below it.
By their numbers in this assay, from the lowest: compounds 1 and 2 (each within the scatter of the next); then compound 4; then compound 3.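

In this assay, the exchange on the double-bonded chain carbon bound to a double-bonded chain carbon and a sulfonyl sulfur can now be read directly: cyano in place of benzoyl lowers the number (a 3.5-fold lower number from compound 3 to compound 4 (0.54 log units; beyond the scatter)), while cyano in place of acetyl raises it (a 2.6-fold higher number from compound 2 to compound 4 (0.41 log units; beyond the scatter)), so at this place cyano falls between the other two groups and does not give the lowest number. Hydrogen in place of methoxy on an aromatic carbon also raises the number (a 4.4-fold higher number from compound 1 to compound 4 (0.64 log units; beyond the scatter)), so the low number of compound 1 cannot be credited to the cyano group alone. Nothing available explains why either change moves the number.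

The compounds shown leave open whether methoxy on that aromatic carbon would also lower the number with acetyl or benzoyl at the chain carbon, as the methoxy exchange is seen here only with cyano. They also leave open where a carboxylic acid, a methyl ester or a primary amide at the chain carbon would fall relative to acetyl and cyano.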